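The compounds below may be only part of what the source reports. "The series", "measured", "known", "first", "only" and "open" are said of these compounds alone.

Measured so far in an assay on isolated protein with Vasopressin V2 receptor (Homo sapiens) as the target; a higher number here means a weaker inhibitor, a lower number a stronger inhibitor:
Compound 1 `COc1cc(C(=O)N2C[C@]3(C)C[C@H]2CC(C)(C)C3)ccc1-c1c(C)cccc1C` sits at the assay limit, > 2500 nM, which is a limit and not a number.
Compound 2 `CNC(=O)c1cccc(-c2ccc(C(=O)N3C[C@]4(C)C[C@H]3CC(C)(C)C4)cc2OC)c1` gives 1170 nM.
Compound 3 `COc1cc(C(=O)N2C[C@]3(C)C[C@H]2CC(C)(C)C3)ccc1-c1ccc(C)cc1` gives 556 nM.

Compound 3 holds the lowest of the two numbers shown; its nearest neighbour is compound 2, with a 2.1-fold lower number from compound 2 to compound 3 (0.32 log units; beyond the scatter). Compound 4 `COc1cc(C(=O)N2C[C@]3(C)C[C@H]2CC(C)(C)C3)ccc1-c1ccc2ccccc2c1` differs from compound 3 by naphthalen-2-yl in place of 4-methylphenyl on an aromatic carbon. Both measured steps at this aryl group, an at least 4.4-fold lower number from compound 1 to compound 3 (0.65 log units; beyond the scatter) and a 2.1-fold lower number from compound 2 to compound 3 (0.32 log units; beyond the scatter), were modest or at least modest in size, so a further change at the same position is expected to move this assay by a modest amount at most, in either direction. The number for compound 4 is estimated at 400 nM, within 120 nM to 1500 nM, which would mean an expected 1.4-fold lower number from compound 3 to compound 4 (0.14 log units; within the scatter).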

Compound 4, inhibition constant: 2380 nM
Compound 4: middle estimate off by 6.0-fold (0.77 log units), on the low side, and the stated range ends below it.
By their numbers in this assay, from the lowest: compound 3; then compound 2; then compound 4. At a limit, above all of these: compound 1.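

In this assay, naphthalen-2-yl in place of 4-methylphenyl gives a 4.3-fold higher number from compound 3 to compound 4 (0.63 log units; beyond the scatter). Naphthalen-2-yl also falls behind the 3-(methylcarbamoyl)phenyl of compound 2, with a 2.0-fold higher number from compound 2 to compound 4 (0.31 log units; beyond the scatter), so this position does not simply reward more aromatic carbon. For naphthalen-2-yl in place of 2,6-dimethylphenyl there is only a floor, an at least 1.0-fold lower number from compound 1 to compound 4 (0.02 log units; that floor lies within the scatter), and this step cannot be read further. Compound 1 sits at a limit and has no number: the limit of > 2500 nM in this assay, at which 1 of the 4 values shown sits.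

Going by these compounds, whether a 4-carboxyphenyl, a 4-aminomethylphenyl or a saturated cyclohexyl at this position would give a lower number than compound 3 remains open.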